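A wider aryl change at the chain end of compound 3

The compounds below may be only part of what the source reports. "The series", "measured", "known", "first", "only" and "open" are said of these compounds alone.

Three analogues built on one shared core have been tested in an ADME assay on the whole organism for cytotoxicity, with Artemia salina as the target, with a stated time of 24 h; a lower number here means that less compound is needed, a higher number that more compound is needed for the effect. Compound 1 `COc1cccc(/C=C/C(=O)c2ccccc2NC(=O)NS(=O)(=O)c2ccc(C)cc2)c1` gives 23.2 ug/mL, compound 2 `COc1ccc(/C=C/C(=O)c2ccccc2NC(=O)NS(=O)(=O)c2ccc(C)cc2)cc1` gives 28.1 ug/mL, and compound 3 `Cc1ccc(S(=O)(=O)NC(=O)Nc2ccccc2C(=O)/C=C/c2ccccc2O)cc1` gives 32.3 ug/mL. Compound 3 thus holds the largest of the three numbers, yet a 1.4-fold higher number from compound 1 to compound 3 (0.14 log units; within the scatter) and a 1.1-fold higher number from compound 2 to compound 3 (0.06 log units; within the scatter) both stay inside the usual scatter, as does a 1.2-fold higher number from compound 1 to compound 2 (0.08 log units; within the scatter). The three compounds differ only in the aryl group on the double-bonded chain carbon, and none of those exchanges moved this assay beyond its noise.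

Compound 4 `CCOc1cc(/C=C/C(=O)c2ccccc2NC(=O)NS(=O)(=O)c2ccc(C)cc2)ccc1O` has not yet been measured. It differs from compound 3 by 3-ethoxy-4-hydroxyphenyl in place of 2-hydroxyphenyl on a double-bonded chain carbon bound to a double-bonded chain carbon. All three measured steps bear on this change, since each likewise replaces the aryl group at that place, and each was small. A hydroxy group already sits on that ring in compound 3, and a methoxy group in two positions on compound 1 and compound 2 gave no step beyond the scatter either. The expected step of a 1.1-fold lower number from compound 3 to compound 4 (0.03 log units; within the scatter) is therefore one of no change beyond the scatter. Compound 4 is estimated to give 30 ug/mL in this assay, within a range from 15 ug/mL to 60 ug/mL.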

Compound 4, concentration for half-maximal effect: 19.2 ug/mL
Estimate against measurement, compound 4: 1.6-fold (0.19 log units) above; the range from low to high includes it.
By their numbers in this assay, from the lowest: compounds 4, 1, 2 and 3 (each within the scatter of the next).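

The 3-ethoxy-4-hydroxyphenyl group brings 10 heavy atoms where the 2-hydroxyphenyl it replaces has 7, and it puts both a hydroxy and an ethoxy group on one aryl ring, whereas each earlier compound carried a single group there. Even so, this wider exchange on a double-bonded chain carbon bound to a double-bonded chain carbon stays inside the scatter of this assay against all three earlier compounds (a 1.7-fold lower number from compound 3 to compound 4 (0.23 log units; within the scatter); a 1.5-fold lower number from compound 2 to compound 4 (0.17 log units; within the scatter); a 1.2-fold lower number from compound 1 to compound 4 (0.08 log units; within the scatter)). Among these four compounds, then, the position tolerates a two-group aryl ring as well as a one-group ring with no separable change in the read-out, and no independent measurement is available that could explain the values of any of them.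

From the compounds shown here alone, whether an amine or a carboxylic acid on that aryl ring, or a chain longer than the ethoxy group, would carry the number beyond the scatter remains open. Going by these compounds, the four compounds also vary only this one place, so the effect of any change elsewhere on the shared core remains unknown.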